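The source may report more compounds than this note shows. Statements on the series, on what has been measured and on what is new or still open speak of the compounds shown alone.

Measured so far in a functional assay on MIA PaCa-2 cells (Homo sapiens) for antiproliferative activity; a lower number here means that less compound is needed, a higher number that more compound is needed for the effect
Compound 1 `Cc1cc2c(C(N)=O)cccc2n1-c1nc2c(c(NCc3ccccc3)n1)CCCC2` gives 128 nM
Compound 2 `CC#CCNC(=O)c1cccc2c1cc(C)n2-c1nc2c(c(NCc3ccccc3)n1)CCCC2` gives 723 nM
Compound 3 `CC#CCNC(=O)c1cccc2c1cc(C)n2-c1nc2c(c(NCc3ccccc3)n1)COCC2` gives 524 nM

Compound 2 at 723 nM lies within the scatter of compound 3 at 524 nM and needs more compound than compound 1 at 128 nM on these numbers. Among the measured compounds shown here, the one measured step is a 5.6-fold higher number from compound 1 to compound 2 (0.75 log units; beyond the scatter), with but-2-yn-1-yl in place of hydrogen on an amide-type nitrogen.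

Compound 4 `CCCC#CC(=O)Nc1cccc2c1cc(C)n2-c1nc2c(c(NCc3ccccc3)n1)CCCC2` has not yet been measured. The change to it is a group of 8 heavy atoms (6 carbon, 1 nitrogen, 1 oxygen; no ring) in place of a group of 7 heavy atoms (5 carbon, 1 nitrogen, 1 oxygen; no ring), on an aromatic carbon, and both groups hold one double bond and one triple bond outside aromatic rings. For the measured compounds named here, the measured step touches the same group and shows that a change there can move the number in this assay, yet no measured step swaps one such group for another. No step beyond the scatter is therefore firmly expected, with a slight lean towards a higher number. The expected step is a 1.4-fold higher number from compound 2 to compound 4 (0.14 log units; within the scatter), and this estimate carries wide margins. Compound 4 is estimated at 1000 nM, with an expected range from 300 nM to 3500 nM.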

Compound 4, half-maximal effective concentration: 1570 nM
Compound 4: middle estimate off by 1.6-fold (0.20 log units), on the low side; measured number inside the range.
By their numbers in this assay, from the lowest: compound 1; then compounds 3 and 2 (each within the scatter of the next); then compound 4.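

In this assay, a 2.2-fold higher number from compound 2 to compound 4 (0.34 log units; beyond the scatter) shows that this aromatic carbon responds to an exchange of one group for another, not only to the replacement of a hydrogen on the amide-type nitrogen: the group of 8 heavy atoms and the group of 7 heavy atoms hold the same counts of double bonds, triple bonds, hydrogen-bond donors and acceptors. Measured against the smaller group in compound 1, the new group gives a wider gap, a 12-fold higher number from compound 1 to compound 4 (1.09 log units; beyond the scatter), so both larger groups tested here give higher numbers than the smaller one. No measurement at hand explains either step.

One pair cannot separate the effect of the added carbon from that of the different arrangement of atoms within the group. Going by these compounds, how an amine, a carboxylic acid or a longer saturated chain would behave on this aromatic carbon remains open.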